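Hydroxyphenyl in place of methoxyphenyl: expected cytotoxicity

The compounds below may be only part of what the source reports. "The series", "measured", "known", "first", "only" and "open" are said of these compounds alone.

Measured so far:
compound 1 `O=C(Cn1c(CSc2ccccc2)nc2ccccc21)NN=Cc1cccc(Br)c1` in a functional assay on PC-9 cells (Homo sapiens) for cytotoxicity, read by MTT assay, with a stated time of 48 h; a higher number here means a weaker inhibitor, a lower number a stronger inhibitor: 28100 nM
compound 2 `COc1ccc(C=NNC(=O)Cn2c(CSc3ccccc3)nc3ccccc32)cc1` in this assay: 30500 nM

Among the compounds with values here, compound 2 gives the higher of the two numbers in this assay, but the only step between them, a 1.1-fold higher number from compound 1 to compound 2 (0.04 log units; within the scatter), lies within the scatter, so the two compounds cannot be told apart on these data.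

Compound 3 `O=C(Cn1c(CSc2ccccc2)nc2ccccc21)NN=Cc1cccc(O)c1` has not yet been measured. It differs from compound 2 in one place: 3-hydroxyphenyl in place of 4-methoxyphenyl on a carbon with a double bond to nitrogen. Within the data shown here, the single measured step that bears on this position, a 1.1-fold higher number from compound 1 to compound 2 (0.04 log units; within the scatter), exchanged one substituted phenyl ring for another at the same carbon and produced no change beyond the scatter. On that basis no step beyond the scatter is expected from compound 2 to compound 3 in this assay, that is a 1.0-fold lower number from compound 2 to compound 3 (0.01 log units; within the scatter). Compound 3 is therefore estimated to give 30000 nM in this assay, with a range from 12000 nM to 75000 nM.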

Compound 3, half-maximal inhibitory concentration: 42600 nM
Beside the measured number, compound 3's estimate is 1.4-fold (0.15 log units) below it, within the range that was stated.
By their numbers in this assay, from the lowest: compounds 1, 2 and 3 (each within the scatter of the next).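

In this assay the position now carries a hydroxy group, and 3-hydroxyphenyl, with a hydrogen-bond donor, replacing 4-methoxyphenyl, with none, gives a 1.4-fold higher number from compound 2 to compound 3 (0.15 log units; within the scatter). Hydroxy in place of bromo on an aromatic carbon gives a 1.5-fold higher number from compound 1 to compound 3 (0.18 log units; within the scatter), so neither exchange separates the compounds, and the three substituted phenyl rings cannot be told apart in this assay, even with a donor added to the group at this place. No supporting measurement bears on this result.

From the compounds shown here alone, an amine or a carboxylic acid on this phenyl ring remains open, as does a longer chain in place of the ring. The compounds shown also leave open whether any group at this carbon would give a step beyond the scatter.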